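Adding a 2-hydroxyethoxy group to compound 3

This account rests on a few compounds, and the source may have more. Where it says the series, first, only, none or still open, it means among the compounds named here.

Measured in a functional assay on HeLa cells (Homo sapiens) for inhibition; on this read-out lower numbers stand for stronger inhibition and higher numbers for weaker inhibition:
compound 1 `Nc1ccn(/C=C/C=O)c(=O)n1`: > 100000 nM, a limit of the assay
compound 2 `Nc1nc(O)c2ncn(/C=C/C=O)c2n1`: > 100000 nM, a limit of the assay
compound 3 `Cc1cn(C)c(=O)n(/C=C/C=O)c1=O`: 10000 nM

For the measured compounds named here, compound 3 at 10000 nM holds the only actual number in the set. Going by the values given here, the other two results are limits, so no measured step can be sized.

Compound 4 `Cc1cn(COCCO)c(=O)n(/C=C/C=O)c1=O` is the next case, and its difference from compound 3 is 2-hydroxyethoxy in place of hydrogen on a saturated chain carbon bound to an aromatic nitrogen. In words, this is 2-hydroxyethoxy in place of hydrogen on a saturated chain carbon bound to an aromatic nitrogen, or methyl to (2-hydroxyethoxy)methyl when cut one bond further out.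

Among the compounds with values here, no measured pair in the set shows this change, so any forecast for this assay is loose and rests on compound 3 at 10000 nM alone. A modest weakening is expected, and a result within the scatter of compound 3 would not be surprising. The expected step is a 2.0-fold higher number from compound 3 to compound 4 (0.30 log units; within the scatter). For compound 4 the estimated value is 20000 nM, with an expected range of 5000 nM to 100000 nM.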

Compound 4, half-maximal inhibitory concentration: 20000 nM
Beside the measured number, compound 4's estimate shows no gap at the digits printed; the measured number falls inside the stated range.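

In this assay the series now has its first readable step, with a 2.0-fold higher number from compound 3 to compound 4 (0.30 log units; within the scatter) for 2-hydroxyethoxy in place of hydrogen on a saturated chain carbon bound to an aromatic nitrogen. Compound 3 alone said nothing about this place, whereas this pair shows that a chain of 4 heavy atoms can enter there with the read-out staying within the scatter. No other step can be read, and compound 1 and compound 2 add nothing to this position: the limit of > 100000 nM in this assay, at which 2 of the 4 values shown sit.

From the compounds shown here alone, whether the terminal hydroxyl matters stays open, since a 2-methoxyethoxy or plain ethoxy group at the same place would be needed to separate it from the chain itself. A longer chain, an amine or a carboxylic acid there is also untested in the compounds shown, so how much room this position allows remains unknown.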